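Ethoxy for Chloro on a Prostacyclin Receptor Ligand

The compounds below may be only part of what the source reports. "The series", "measured", "known", "first", "only" and "open" are said of these compounds alone.

Measured compounds:
- compound 1, `CC/N=C(\N)Nc1ccc(Sc2ccc(Cl)cc2)cc1`: 631 nM
- compound 2, `CC/N=C(\N)NCc1ccc(Sc2ccc(Cl)cc2)cc1`: < 10000 nM
- compound 3, `Clc1ccc(Sc2ccc(NC3=NCCN3)cc2)cc1`: 79.4 nM

All three were tested in an assay (Rattus norvegicus) for binding affinity to prostacyclin receptor (Homo sapiens), read by radioligand binding; a higher number here means a weaker inhibitor, a lower number a stronger inhibitor. Compound 2 reached only a limit of this assay, < 10000 nM, so its number is not known; this is the limit described as the limit of < 10000 nM in this assay, at which 1 of the 3 values shown sits. Because of that limit, the steps a step that the limit leaves unreadable from compound 1 to compound 2 and a step that the limit leaves unreadable from compound 2 to compound 3 cannot be read. Among the compounds with values here, the one readable step is a 7.9-fold lower number from compound 1 to compound 3 (0.90 log units; beyond the scatter), which puts compound 3 at the lowest of the two known numbers, with compound 1 as its nearest neighbour.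

Compound 4, `CCOc1ccc(Sc2ccc(NC3=NCCN3)cc2)cc1`, differs from compound 3 by ethoxy in place of chloro on an aromatic carbon. Within the data shown here, none of the measured steps touches this part of the molecule; every readable change so far sits on the other end of the shared core. With nothing to point either way, the expectation is a step of a 1.3-fold higher number from compound 3 to compound 4 (0.10 log units; within the scatter), within the scatter. Compound 4 is therefore estimated at 100 nM, with a range from 25 nM to 400 nM.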

Compound 4, inhibition constant: 39.8 nM
Compound 4: the middle estimate sits 2.5-fold (0.40 log units) above what was measured; measured number inside the range.
By their numbers in this assay, from the lowest: compounds 4 and 3 (each within the scatter of the next); then compound 1.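

Within the data shown here, this is the first change at this end of the molecule, on an aromatic carbon para to a large group, and in this assay it gives a 2.0-fold lower number from compound 3 to compound 4 (0.30 log units; within the scatter). Ethoxy brings more heavy atoms than chloro and a hydrogen-bond acceptor that chloro lacks, yet the two compounds cannot be told apart in this assay, so this position accepts at least this one larger group without a change beyond the scatter. Nothing measured here explains why the swap leaves the number within the scatter.

The compounds shown leave open whether this holds for a longer chain, an amine or a carboxylic acid at the same position. As far as these compounds go, they also leave open what a plain hydrogen there would give, so the contribution of either chloro or ethoxy remains unknown.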